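The source may report more compounds than this note shows. Statements on the series, on what has been measured and on what is new or still open speak of the compounds shown alone.

Compound 1 `CCCCCCCCCNC(=O)Oc1ccc(Cl)cc1C(=O)Nc1cccc(Cl)c1` and compound 2 `CCCCCCCCCCNC(=O)Oc1ccc(Cl)cc1C(=O)Nc1cccc(Cl)c1` share one core, while compound 3 `CCCCCCNC(=O)Oc1ccc(Cl)cc1C(=O)Nc1ccc(Cl)c(Cl)c1` and compound 4 `CCCCCCCNC(=O)Oc1ccc(Cl)cc1C(=O)Nc1ccc(Cl)c(Cl)c1` share another; the difference between the two cores is not broken down here. In a physicochemical assay for lipophilicity (a higher number here means a more lipophilic compound, a lower number a more polar compound), compound 1 gives 6.78 and compound 2 gives 7.19, a step of a number 0.41 log units higher from compound 1 to compound 2 (beyond the scatter) made by methyl in place of hydrogen on a saturated chain carbon, nine bonds along the chain from an amide-type nitrogen. In this assay compound 3 gives 6.08, the lowest of the three numbers. Compound 4 arises from compound 3 by methyl in place of hydrogen on a saturated chain carbon, six bonds along the chain from an amide-type nitrogen, the same kind of change as that between compound 1 and compound 2, though the place here is six bonds along the chain from an amide-type nitrogen rather than nine. Because the earlier step was a number 0.41 log units higher from compound 1 to compound 2 (beyond the scatter), a similar step, a number 0.42 log units higher from compound 3 to compound 4 (beyond the scatter), is expected in this assay. Compound 4 is therefore estimated at 6.5, between 6.2 and 6.8.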

Compound 4, partition coefficient: 6.5
Compound 4: the middle estimate sits on the measured number at the digits printed, and the stated range covers the measured number.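

The new step in this assay is a number 0.42 log units higher from compound 3 to compound 4 (beyond the scatter) and stands close in size to the earlier a number 0.41 log units higher from compound 1 to compound 2 (beyond the scatter), so in these two pairs the change carried from the core of compound 1 to the core of compound 3 with much the same result. For the compounds shown here, this rests on only one pair in each core, and the place differs, six bonds along the chain from an amide-type nitrogen in one pair and nine in the other, so it sets no rule for other cores or other places. Nothing measured here explains the agreement between the two steps.

The compounds shown leave open whether the same step would hold in a longer chain. They also leave open what an amine or a carboxylic acid in place of the methyl would do to the number.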